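From compound 3 to its methyl analogue

The source may hold more compounds than are shown below. What is called first, only, known or untested is meant among the compounds shown, and "the series" means these compounds.

Three silyl-bearing compounds have been tested in a functional assay on U-373MG ATCC cells (Homo sapiens) for inhibition, read by MTT assay, with a stated time of 72 h; a higher number here means a weaker inhibitor of growth, a lower number a stronger inhibitor of growth. Compound 1 `CC(C)C(C)(C)[Si](C)(C)OC[C@H]1O[C@@H](n2ccc(=O)[nH]c2=O)[C@H](O)[C@@H]1O` reads > 100000 nM, which is a limit of the assay and not a number. Compound 2 `Cc1cn([C@@H]2O[C@H](CO[Si](C)(C)C(C)(C)C)[C@@H](O)[C@H]2O)c(=O)[nH]c1=O` reads > 100000 nM, again a limit and not a number. Among the compounds with values here, compound 3 `CC(C)[Si]1(C(C)C)OC[C@H]2O[C@@H](n3ccc(=O)[nH]c3=O)[C@H](O)[C@@H]2O[Si](C(C)C)(C(C)C)O1` gives 81000 nM, the only actual number in the set, so it is the one secure reference point. The two limits cannot be set against it as measured differences.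

The next compound to be tested is compound 4 `Cc1cn([C@@H]2O[C@@H]3CO[Si](C(C)C)(C(C)C)O[Si](C(C)C)(C(C)C)O[C@H]3[C@H]2O)c(=O)[nH]c1=O`. It differs from compound 3 in a single place: methyl in place of hydrogen on an aromatic carbon. Within the data shown here, no pair of measured compounds shows what a change of this kind does in this assay, so there is no measured step to carry over. With nothing to suggest a direction, no step beyond the usual scatter is expected, and the estimate stays anchored to compound 3 at 81000 nM. The estimated change is a 1.1-fold lower number from compound 3 to compound 4 (0.03 log units; within the scatter), which is too small to be read as a real shift. Compound 4 is expected to give about 75000 nM, with an estimated range from 30000 nM to 130000 nM.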

Compound 4, concentration for 50% growth inhibition: 87000 nM
Compound 4: the middle estimate sits 1.2-fold (0.06 log units) below what was measured, within the range that was stated.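

Methyl in place of hydrogen on an aromatic carbon, two atoms from the ring nitrogen, gives a 1.1-fold higher number from compound 3 to compound 4 (0.03 log units; within the scatter), the first measured step between two compounds that differ in one place. At this position, the added methyl therefore leaves compound 3 and compound 4 indistinguishable in this assay, and the set now holds two actual numbers instead of one. A limit, which is not a number, caps what this assay can report, and this pair lies not far under it, so there is little room to see any further weakening: the limit of > 100000 nM in this assay, at which 2 of the 4 values shown sit.

What the compounds shown leave open is whether a different group on this same aromatic carbon, such as an ethyl chain, a chlorine atom, an amine or a carboxylic acid, would give a step beyond the scatter, in either direction. Going by these compounds, it also remains open whether methyl would read the same way on the core of compound 1 or compound 2, as the limits of those two compounds cannot be read as steps.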